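Carboxymethyl on the Ring Nitrogen: Expected Cytotoxicity

The source may report more compounds than this note shows. Statements on the series, on what has been measured and on what is new or still open speak of the compounds shown alone.

Measured compounds:
Compound 1, `CCOc1ccc2nc(Cl)c(/C=C3\SC(=S)NC3=O)cc2c1`, > 100 ug/mL
Compound 2, `O=C1NC(=S)S/C1=C\c1cc2cc(Cl)ccc2nc1Cl`, > 100 ug/mL
Compound 3, `O=C1NC(=S)S/C1=C\c1cc2cc(F)ccc2nc1Cl`, > 100 ug/mL

In a toxicity assay on HUVEC cells (Homo sapiens) for cytotoxicity, read by MTT assay, with a stated time of 48 h (a higher number here means a weaker inhibitor of growth, a lower number a stronger inhibitor of growth), compound 1 gives > 100 ug/mL, which is a limit of the assay rather than a number. Compound 2 likewise gives only a limit in this assay, > 100 ug/mL. Compound 3, the starting point here, also gives only a limit in this assay, namely > 100 ug/mL. Because of the limit of > 100 ug/mL in this assay, at which 3 of the 3 values shown sit, none of the three steps among them can be sized: a step that the two limits leave unreadable from compound 1 to compound 2, a step that the two limits leave unreadable from compound 1 to compound 3 and a step that the two limits leave unreadable from compound 2 to compound 3 are all unreadable.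

Compound 4, `O=C(O)CN1C(=O)/C(=C/c2cc3cc(F)ccc3nc2Cl)SC1=S`, differs from compound 3 by carboxymethyl in place of hydrogen on an amide-type nitrogen in a ring. Among the compounds with values here, no measured step touches this nitrogen, so no step among the measured compounds bears on the change directly; the only guide is that every compound sharing this core sits at the limit. The expectation is therefore a step that the limit leaves unreadable from compound 3 to compound 4 in this assay, that is, none beyond the scatter, and most likely again only a limit. Compound 4 is estimated at 150 ug/mL in this assay, with a range from 60 ug/mL to 400 ug/mL.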

Compound 4, concentration for 50% growth inhibition: > 100 ug/mL
Compound 4: a limit, no number; the forecaster's own chance of this, stated with the estimate: 80%; the middle value does not contradict the limit.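

Compound 4, like compound 3, gives only a limit in this assay, so no new step can be read for carboxymethyl in place of hydrogen on the amide-type nitrogen in the ring: the limit of > 100 ug/mL in this assay, at which 4 of the 4 values shown sit.

The compounds shown leave open at what concentration, if any, each of them would inhibit growth in this assay.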